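A few compounds are considered here, and "the series" means these few. Any claim that something is new, unique, unknown or untested is made for them only; others in the source may bear on it.

In an assay on Sf9 cells for inhibition of protein deacetylase HDAC6 (Homo sapiens), read by fluorescence, with a stated time of 40 min, tested at 100 nM (a higher number here means more inhibition at the concentration tested (going by the name of the read-out), a lower number less inhibition), the measured compounds are: compound 1 `O=C(NO)c1ccc(NCc2nc(-c3ccco3)nn2-c2ccccc2)cc1` giving 59.9%; compound 2 `COc1ccc(-c2nc(CNc3ccc(C(=O)NO)cc3)n(-c3ccccc3)n2)cc1` giving 77.6%; compound 3 `CCc1ccc(-c2nc(CNc3ccc(C(=O)NO)cc3)n(-c3ccccc3)n2)cc1` giving 54.6%.

Compound 3 holds the lowest of the three numbers. Its nearest neighbour is compound 1, which lies within the scatter of it (a number 5.3 percentage points lower from compound 1 to compound 3 (within the scatter)), while compound 2 stands furthest away (a number 23 percentage points lower from compound 2 to compound 3 (beyond the scatter)). Compound 4 `O=C(NO)c1ccc(NCc2nc(-c3ccccn3)nn2-c2ccccc2)cc1` differs from compound 3 in one place: pyridin-2-yl in place of 4-ethylphenyl on an aromatic carbon. Among the compounds with values here, the steps that bear on this change are those at the same aromatic carbon: a number 17.7 percentage points higher from compound 1 to compound 2 (beyond the scatter) and a number 5.3 percentage points lower from compound 1 to compound 3 (within the scatter). A five-membered heteroaryl there, in compound 1, sat within the scatter of compound 3, so no step beyond the scatter is expected in this assay, perhaps a small rise (a number 5.4 percentage points higher from compound 3 to compound 4 (within the scatter)). Compound 4 is therefore estimated at 60%, within 42% to 78%.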

Compound 4, a percentage reported as inhibition, at one concentration (the size of the read-out at that concentration, not a potency): 58.6%
Compound 4: middle estimate off by 1.4 percentage points, on the high side, within the range that was stated.
By their numbers in this assay, from the lowest: compounds 3, 4 and 1 (each within the scatter of the next); then compound 2.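

In this assay, a six-membered ring with a ring nitrogen at this carbon proves no different from the five-membered furan-2-yl (a number 1.3 percentage points lower from compound 1 to compound 4 (within the scatter)) or the all-carbon 4-ethylphenyl (a number 4 percentage points higher from compound 3 to compound 4 (within the scatter)). Among the four compounds, only compound 2 stands apart, and pyridin-2-yl does not match it (a number 19 percentage points lower from compound 2 to compound 4 (beyond the scatter)). Nothing at hand explains these numbers.

On these data alone, it remains open whether 4-aminophenyl or 4-carboxyphenyl at this carbon would side with compound 2 or with the others. As far as these compounds go, it is also open whether pyridin-3-yl would match pyridin-2-yl.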